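Ring size on the urea nitrogen: cyclopentyl to cyclooctyl

The source may report more compounds than this note shows. Statements on the series, on what has been measured and on what is new or still open speak of the compounds shown alone.

Of the compounds shown here, two have numbers so far, both read in a functional assay on the whole organism for inhibition, with Rattus norvegicus as the target, at a dose of 30 mg/kg by the oral route; on this read-out higher numbers stand for more inhibition at the one dose given (going by the name of the read-out) and lower numbers for less inhibition. Compound 1 `CN(C(=O)NCCCOc1ccc2nc(O)ccc2c1)C1CCCCC1` gives 15% in this assay. Compound 2 `O=C(NCCCOc1ccc2nc(O)ccc2c1)N(C1CCCC1)[C@H]1CCCC[C@@H]1O` gives 20% in this assay; this value sits within the scatter of that of compound 1, so the two cannot be told apart on the numbers shown, and neither read-out is more than modest.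

Compound 3 `O=C(NCCCOc1ccc2nc(O)ccc2c1)N(C1CCCCCCC1)[C@H]1CCCC[C@@H]1O` is the next member: cyclooctyl in place of cyclopentyl on an amide-type nitrogen. Nothing measured in the series speaks to a change of this ring size, so the expectation rests on compound 2 alone. The step from compound 2 to compound 3 is expected to be no change at the digits printed from compound 2 to compound 3 (within the scatter), which is taken as no change beyond the scatter. For compound 3 the estimate in this assay is 20%, with a range from 5% to 40%.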

Compound 3, a percentage reported as inhibition, in the whole organism at one dose (the size of the read-out at that dose, not a potency): 27%
Compound 3: middle estimate off by 7 percentage points, on the low side, within the range that was stated.
By their numbers in this assay, from the lowest: compounds 1, 2 and 3 (each within the scatter of the next, the first and the last beyond it).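

Replacing cyclopentyl with cyclooctyl on the amide-type nitrogen gives a number 7 percentage points higher from compound 2 to compound 3 (within the scatter) in this assay. Among the compounds shown here, this is the first reading at this position, and it shows that a carbocycle of eight members in place of one of five leaves the read-out at one dose within the scatter, so this change of ring size cannot be told apart on these numbers. Nothing on hand speaks to the reason for this outcome.

Cyclohexyl and cycloheptyl at this place remain open, so the two rings read here give no trend across ring sizes. Also open, as far as these compounds go, is whether an open chain such as n-hexyl, or a ring carrying an amine such as piperidinyl, would read differently from these carbocycles.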